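From amino to carboxy at the assay limit

This account rests on a few compounds, and the source may have more. Where it says the series, first, only, none or still open, it means among the compounds named here.

In a toxicity assay on MDCK cells (Canis lupus familiaris) for cytotoxicity, read by CCK-8 assay, with a stated time of 48 h (on this read-out higher numbers stand for lower toxicity in this test and lower numbers for higher toxicity in this test), compound 1 (`COc1ccc(C(=O)NNc2c(Br)cccc2Br)cc1`) gives > 100000 nM, which is a limit of the assay and not a number. Compound 2 (`Nc1ccc(C(=O)NNc2c(Br)cccc2Br)cc1`) gives > 100000 nM, which is again a limit, so it has no exact standing on the numbers. Both values sit together, as the limit of > 100000 nM in this assay, at which 2 of the 2 values shown sit, shows.

Going by the values given here, the only measured step is a step that the two limits leave unreadable from compound 1 to compound 2, with amino in place of methoxy on an aromatic carbon. It supplies no size to carry forward.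

Compound 3 (`O=C(O)c1ccc(C(=O)NNc2c(Br)cccc2Br)cc1`) has carboxy in place of amino on an aromatic carbon, para to a large group: carboxy in place of amino on an aromatic carbon. Among the compounds with values here, no measured compound carries this carboxy group.

Compound 3 is expected at the same limit because compound 2 gives > 100000 nM. No step beyond the usual scatter is expected in this assay, and no direction is expected either. The expected change is a number no higher from compound 2 to compound 3 (the limit leaves the size open). The estimate for compound 3 is 100000 nM, with an expected range of 40000 nM to 250000 nM.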

Compound 3, half-maximal cytotoxic concentration: > 100000 nM
Compound 3 was reported as a limit (the forecaster's own chance of this, stated with the estimate: 85%); the middle value sits exactly at the limit.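

In this assay compound 3 gives > 100000 nM, which is a limit of the assay and not a number. No step among compound 1, compound 2 and compound 3 can be read, as all three share one limit: the limit of > 100000 nM in this assay, at which 3 of the 3 values shown sit.

The compounds shown leave open whether any substituent at this aromatic carbon gives an exact value in this assay.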